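Chloro to Fluoro Repeated on a Second Core

A few compounds are considered here, and "the series" means these few. Any claim that something is new, unique, unknown or untested is made for them only; others in the source may bear on it.

Three compounds have been measured in a functional assay on the whole organism (artery, strain albino) with Rattus norvegicus as the target, with a stated time of 240 min, at a dose of 10 mg/kg by the oral route; a lower number here means less inhibition, a higher number more inhibition at the dose given (going by the name of the read-out):

Compound 1, `COc1ccc(C2N=C(SCc3ccc(Cl)cc3)NC(C)=C2C(=O)Nc2ccc(F)cc2)cc1OC`, gives 24.1%.
Compound 2, `COc1ccc(C2N=C(SCc3ccc(F)cc3)NC(C)=C2C(=O)Nc2ccc(F)cc2)cc1OC`, gives 28.7%.
Compound 3, `CC1=C(C(=O)Nc2ccc(F)cc2)C(c2ccc([N+](=O)[O-])cc2)N=C(SCc2ccc(Cl)cc2)N1`, gives 33.3%.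

Compound 1 and compound 2 differ by one change, (fluoro in place of chloro on an aromatic carbon), and this change gave a number 4.6 percentage points higher from compound 1 to compound 2 (within the scatter). Compound 3 stands on a different core from compound 1; the difference between the two cores is 4-nitrophenyl in place of 3,4-dimethoxyphenyl on a saturated ring carbon, and it gave a number 9.2 percentage points higher from compound 1 to compound 3 (within the scatter). All three measured numbers lie close together, so none of them can be set apart from the others.

Compound 4, `CC1=C(C(=O)Nc2ccc(F)cc2)C(c2ccc([N+](=O)[O-])cc2)N=C(SCc2ccc(F)cc2)N1`, has not yet been measured in this assay. It differs from compound 3 by fluoro in place of chloro on an aromatic carbon. This is the same change that leads from compound 1 to compound 2, made here on the core of compound 3; it occurs twice among the compounds described, once measured and once not. Among the measured compounds shown here, because the only measured instance of this change gave a number 4.6 percentage points higher from compound 1 to compound 2 (within the scatter), the step from compound 3 to compound 4 is expected to be of similar size, estimated as a number 4.6 percentage points higher from compound 3 to compound 4 (within the scatter). On that basis, and resting on the value of compound 3 of 33.3%, compound 4 is estimated to give 37.9% in this assay, with an expected range from 25% to 50%. Whether the second core carries the change in the same way remains to be seen once compound 4 is measured.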

Compound 4, a percentage reported as inhibition, in the whole organism at one dose (the size of the read-out at that dose, not a potency): 25.6%
Beside the measured number, compound 4's estimate is 12.3 percentage points above it, within the range that was stated.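

In this assay, fluoro in place of chloro on the core of compound 3 gave a number 7.7 percentage points lower from compound 3 to compound 4 (within the scatter), and this step does not stand apart from the earlier instance of the same change: the same change on two cores in this assay, a number 4.6 percentage points higher (within the scatter) from compound 1 to compound 2 and a number 7.7 percentage points lower (within the scatter) from compound 3 to compound 4, 12.3 percentage points apart, within the scatter of two such steps. The exchange of 3,4-dimethoxyphenyl for 4-nitrophenyl, read with fluoro on the benzyl group, gave a number 3.1 percentage points lower from compound 2 to compound 4 (within the scatter), and it likewise does not stand apart from its earlier instance: the same change on two cores in this assay, a number 9.2 percentage points higher (within the scatter) from compound 1 to compound 3 and a number 3.1 percentage points lower (within the scatter) from compound 2 to compound 4, 12.3 percentage points apart, within the scatter of two such steps. Neither change is therefore shown to act differently on one core than on the other, but this does not show that either change carries over, as every step lies within the scatter and each comparison rests on only two steps.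

The compounds shown leave open how the numbers would respond if the halogen on the benzyl group gave way to a methoxy group, a nitrile or an amine, changes that might produce steps large enough to read from one core to the other. They also leave open whether a carboxylic acid or a longer chain in place of the benzyl group would give a step that could be told from the scatter.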